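The source may hold more compounds than are shown below. What is called first, only, known or untested is meant among the compounds shown, and "the series" means these compounds.

Of the compounds shown here, two built on one shared core have so far been tested in a functional assay on HCC1806 cells (Homo sapiens) for inhibition, read by sulforhodamine B assay, tested at 10 uM; on this read-out higher numbers stand for more inhibition at the one concentration tested (going by the name of the read-out) and lower numbers for less inhibition. Compound 1 `CN1CCN(c2ccc(C3=NN(S(=O)(=O)C4CC4)C(c4ccc(N(C)C)cc4)C3)cc2)CC1` gives 4.7% in this assay, a small effect at the single concentration used. Compound 2 `COC(=O)CC(=O)N1N=C(c2ccc(-n3cncn3)cc2)CC1c1ccc(N(C)C)cc1` gives -7.8% in this assay, the lowest of the two numbers; its nearest neighbour is compound 1, whose value is higher by an amount beyond the usual scatter of repeated measurements, so the inhibition of compound 2 in this assay is the lower of the pair. Compound 3 `CN(C)c1ccc(C2CC(c3ccc(-n4cncn4)cc3)=NN2S(=O)(=O)c2ccc(C#N)cc2)cc1` has not yet been measured. It differs from compound 2 in one place: (4-cyanophenyl)sulfonyl in place of ((methoxycarbonyl)methyl)carbonyl on an amine nitrogen in a ring. Among the compounds with values here, no step between two measured compounds covers this particular change, so its effect cannot be read directly from the numbers at hand. Compound 1, which also carries a sulfonyl group, gives 4.7% in this assay, which hints that a sulfonyl on this core sits a little above compound 2. Compound 3 is therefore expected to show a modest rise, a number 12.8 percentage points higher from compound 2 to compound 3 (beyond the scatter), toward more inhibition, though the step may still fall within the scatter. Compound 3 is estimated at 5%, with a range from -10% to 25%.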

Compound 3, a percentage reported as inhibition, at one concentration (the size of the read-out at that concentration, not a potency): 33.1%
Estimate against measurement, compound 3: 28.1 percentage points below, outside the stated range (above it).
By their numbers in this assay, from the lowest: compound 2; then compound 1; then compound 3.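

In this assay, the group on an amine nitrogen in a ring of the shared core proves to matter a great deal: putting (4-cyanophenyl)sulfonyl in place of ((methoxycarbonyl)methyl)carbonyl gives a number 40.9 percentage points higher from compound 2 to compound 3 (beyond the scatter). Within the data shown here, this is the first comparison in which only one place changes and the rest of the molecule stays the same, so the shift can be tied to this swap, which the two earlier compounds could not show. Nothing available explains why the number rises, and the data say nothing about a cause.

The swap changes several things at once, bringing in a sulfonyl link, a six-membered aromatic ring of carbon only and a nitrile, so the step cannot show which of these parts accounts for the rise. On these data alone, a phenylsulfonyl group without the nitrile, or a 4-cyanobenzoyl group with a carbonyl in place of the sulfonyl, would help separate them, and since each number comes from one concentration, how potent compound 3 is also remains open.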